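Removing a methoxy group from the trimethoxyphenyl end of compound 2

The compounds below may be only part of what the source reports. "The series", "measured", "known", "first", "only" and "open" are said of these compounds alone.

Measured so far:
compound 1, `COc1ccccc1/C=C/C(=O)/C=C/c1ccc(OCc2cn(CCOc3cc(=O)oc4ccccc34)nn2)c(OC)c1`, 11500 nM
compound 2, `COc1cc(/C=C/C(=O)/C=C/c2cc(OC)c(OC)c(OC)c2)ccc1OCc1cn(CCCOc2cc(=O)oc3ccccc23)nn1`, 10600 nM
compound 3, `COc1ccc(/C=C/C(=O)/C=C/c2ccc(OCc3cn(CCOc4cc(=O)oc5ccccc45)nn3)c(OC)c2)cc1`, 11300 nM

All three were tested in a functional assay on COLO 205 cells (Homo sapiens) for cytotoxicity, read by sulforhodamine B assay, with a stated time of 48 h; on this read-out lower numbers stand for stronger inhibition and higher numbers for weaker inhibition. Compound 2 gives the lowest of the three numbers, yet its distances to compound 3 and to compound 1 are both within the scatter, so the three compounds cannot be told apart on this read-out. Among the measured compounds shown here, the only step between compounds differing in one place, a 1.0-fold lower number from compound 1 to compound 3 (0.01 log units; within the scatter), concerns the methoxyphenyl at the far end and is within the scatter.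

Compound 4, `COc1ccc(/C=C/C(=O)/C=C/c2ccc(OCc3cn(CCCOc4cc(=O)oc5ccccc45)nn3)c(OC)c2)cc1OC`, is not yet measured. It differs from compound 2 as follows: hydrogen in place of methoxy on an aromatic carbon. For the measured compounds named here, no measured step touches the trimethoxyphenyl side, so no direct precedent exists. Since no variation among the measured compounds has moved the number beyond the scatter, compound 4 is expected to give 11000 nM, with a range from 6000 nM to 21000 nM. This corresponds to an expected step of a 1.0-fold higher number from compound 2 to compound 4 (0.02 log units; within the scatter), no change beyond the scatter.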

Compound 4, half-maximal inhibitory concentration: 13000 nM
Estimate against measurement, compound 4: 1.2-fold (0.07 log units) below, and the stated range covers the measured number.
By their numbers in this assay, from the lowest: compounds 2, 3, 1 and 4 (each within the scatter of the next).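

Among the compounds shown here, replacing the 3,4,5-trimethoxyphenyl end with 3,4-dimethoxyphenyl provides the first measured step on that side of the molecule: in this assay the change gives a 1.2-fold higher number from compound 2 to compound 4 (0.09 log units; within the scatter) and so stays within the scatter. On this read-out, then, hydrogen and methoxy cannot be told apart at this aromatic carbon, ortho to a methoxy group, in this pair of compounds. Nothing measured beyond the cell read-out itself bears on this result.

The compounds shown leave open whether an amine or a carboxylic acid on this same aromatic carbon would move the number beyond the scatter. From the compounds shown here alone, it also remains open whether hydrogen could replace the other methoxy groups on this ring with as little effect on the number.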